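A Fourth Aryl Variant on a Shared Core

The source may report more compounds than this note shows. Statements on the series, on what has been measured and on what is new or still open speak of the compounds shown alone.

Of the compounds shown here, three built on one shared core have been tested in a functional assay on HCT-116 cells (Homo sapiens) for antiproliferative activity, read by MTT assay, with a stated time of 48 h; a higher number here means a weaker inhibitor, a lower number a stronger inhibitor. Compound 1 `CCOc1ccccc1-n1nncc1CN1C(=O)C2(C(C#N)=C(N)Oc3c(N)cc4nc5ccccc5nc4c32)c2ccccc21` gives only a limit, > 50000 nM. Compound 2 `N#CC1=C(N)Oc2c(N)cc3nc4ccccc4nc3c2C12C(=O)N(Cc1cnnn1-c1ccc([N+](=O)[O-])cc1)c1ccccc12` likewise gives only a limit, > 50000 nM. Compound 3 `Cc1ccc(-n2nncc2CN2C(=O)C3(C(C#N)=C(N)Oc4c(N)cc5nc6ccccc6nc5c43)c3ccccc32)cc1C` also gives only a limit, > 50000 nM. Because all three values sit at the limit of > 50000 nM in this assay, at which 3 of the 3 values shown sit, none of the steps among them can be read: a step that the two limits leave unreadable from compound 1 to compound 2, a step that the two limits leave unreadable from compound 1 to compound 3 and a step that the two limits leave unreadable from compound 2 to compound 3. Compound 3 thus stands at the same limit as the other two, with no number of its own.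

Compound 4 `Cc1ccc(Cl)cc1-n1nncc1CN1C(=O)C2(C(C#N)=C(N)Oc3c(N)cc4nc5ccccc5nc4c32)c2ccccc21` differs from compound 3 in one place: 5-chloro-2-methylphenyl in place of 3,4-dimethylphenyl on an aromatic nitrogen. The measured steps that bear on this change are the three just named, and each is unreadable, giving no size and no direction for the coming step in this assay. Swapping one aryl group for another on this aromatic nitrogen has, in every measured case, left the result at the limit. Compound 4 is therefore expected to give 60000 nM, within a range from 20000 nM to 200000 nM, most likely reported again only as a limit. The estimated step that the limit leaves unreadable from compound 3 to compound 4 is expected to be none beyond the scatter.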

Compound 4, half-maximal inhibitory concentration: 37200 nM
Estimate against measurement, compound 4: 1.6-fold (0.21 log units) above; measured number inside the range.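

In this assay, a group on this aromatic nitrogen can give a measured number rather than a limit, and among the four aryl groups shown only 5-chloro-2-methylphenyl does so, while the other three compounds stay at a limit: the limit of > 50000 nM in this assay, at which 3 of the 4 values shown sit.

Set against those limits, the change now has a direction, with an at least 1.3-fold lower number from compound 3 to compound 4 (0.12 log units; that floor lies within the scatter), an at least 1.3-fold lower number from compound 2 to compound 4 (0.12 log units; that floor lies within the scatter) and an at least 1.3-fold lower number from compound 1 to compound 4 (0.12 log units; that floor lies within the scatter). From the compounds shown here alone, each of these is only a floor, so the true size of each step stays unknown, and the other three compounds cannot be ranked against one another.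

The compounds shown do not separate the part played by the chlorine from that of the methyl in 5-chloro-2-methylphenyl. Going by these compounds, whether a bromine or a trifluoromethyl group in place of the chlorine would also give a number remains open.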